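The source may report more compounds than this note shows. Statements on the series, on what has been measured and on what is new or still open speak of the compounds shown alone.

Two compounds share one core and differ only in what hangs from the end of a long saturated chain attached to an aromatic nitrogen. Compound 1 `CNC(=O)CCCCCCCn1nc(-c2cnc3[nH]ccc3c2)c2c(N)ncnc21` carries a methylcarbamoyl cap on that chain; compound 2 `Nc1ncnc2c1c(-c1cnc3[nH]ccc3c1)nn2CCCCCCCCCC(=O)NO` carries a hydroxycarbamoyl cap on a chain three carbons longer. In an assay on isolated protein for inhibition of protein deacetylase HDAC6 (Homo sapiens), with a stated time of 15 min, tested at 1 uM (a lower number here means less inhibition, a higher number more inhibition at the concentration tested (going by the name of the read-out)), compound 1 gives 100% and compound 2 gives 98.3%. Within the data shown here, the one measured step, a number 1.7 percentage points lower from compound 1 to compound 2 (within the scatter), is within the scatter. Compound 2 thus stands as the lower of the two numbers, but by a margin that counts for nothing.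

Compound 3 `Nc1ncnc2c1c(-c1cnc3[nH]ccc3c1)nn2CCCCCCC(=O)NO` keeps the hydroxycarbamoyl cap and shortens the chain: hydroxycarbamoyl in place of 3-(hydroxycarbamoyl)propyl on a saturated chain carbon, six bonds along the chain from an aromatic nitrogen. Among the measured compounds shown here, no measured step describes a change of this kind; the only step seen swapped the cap itself rather than the chain length, and it was within the scatter. With both measured compounds near the top of the scale, the expectation for compound 3 is that this assay stays high, with a step of a number 10.3 percentage points lower from compound 2 to compound 3 (beyond the scatter) allowed mostly toward lower numbers. Compound 3 is therefore estimated at 88%, with a range from 60% to 100%.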

Compound 3, a percentage reported as inhibition, at one concentration (the size of the read-out at that concentration, not a potency): 99.1%
Beside the measured number, compound 3's estimate is 11.1 percentage points below it, and the stated range covers the measured number.
By their numbers in this assay, from the lowest: compounds 2, 3 and 1 (each within the scatter of the next).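

Among these compounds, with the hydroxycarbamoyl cap kept, replacing 3-(hydroxycarbamoyl)propyl with hydroxycarbamoyl at this position gives a number 0.8 percentage points higher from compound 2 to compound 3 (within the scatter) in this assay, so this is the first direct test of chain length, and at this single concentration the read-out does not separate the two lengths. The cap and the chain length change together in a number 0.9 percentage points lower from compound 1 to compound 3 (within the scatter), and that step also stays within the scatter, which means that neither a hydroxycarbamoyl nor a methylcarbamoyl end, on any of the three chains shown, can be told apart from the others by this read-out. All three compounds sit near the top of the scale, where a single-concentration number cannot rank them, and no measurement at hand offers an explanation for this closeness.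

The compounds shown leave open how a carboxylic acid or a primary amide at the end of the chain would read, and whether a chain shorter than that of compound 3 would keep the number this high. They also leave open how a methylcarbamoyl cap would read on the chain of compound 3, a comparison that would change the cap alone.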